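A few compounds are considered here, and "the series" means these few. Any claim that something is new, unique, unknown or untested is made for them only; others in the source may bear on it.

In a functional assay on MDA-MB-231 cells (Homo sapiens) for antiproliferative activity, read by MTT assay, with a stated time of 24 h (a higher number here means a weaker inhibitor, a lower number a stronger inhibitor), compound 1 `O=C(O)CC(NS(=O)(=O)c1ccc(C(F)(F)F)cc1)c1ccccc1` gives 56100 nM and compound 2 `CC(C)(C)c1ccc(C(CC(=O)O)NC(=O)c2ccc(F)cc2)cc1` gives 87600 nM. These two numbers lie within the usual scatter of each other, so compound 2 cannot be told apart from compound 1. Compound 3 `COc1ccccc1C(=O)NC(CC(=O)O)c1ccc(C(C)(C)C)cc1` reads > 100000 nM, which is a limit of the assay and not a number.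

Compound 4 `CC(C)(C)c1ccc(C(CC(=O)O)NC(=O)c2ccc(C(F)(F)F)cc2)cc1` keeps the core of compound 2 and changes a single group: trifluoromethyl in place of fluoro on an aromatic carbon. Trifluoromethyl takes the place of fluoro on an aromatic carbon.

Among the compounds with values here, only one measured step touches this same group: an at least 1.1-fold higher number from compound 2 to compound 3 (0.05 log units; that floor lies within the scatter). It replaces the whole 4-fluorophenyl with 2-methoxyphenyl and shows no change beyond the scatter. Compound 1 also carries a trifluoromethyl group, on a different core, and its 56100 nM gives a similar reading. No step beyond the scatter is therefore expected in this assay. The expected 1.3-fold lower number from compound 2 to compound 4 (0.10 log units; within the scatter) stays small. For compound 4 the estimate is 70000 nM, with an expected range of 35000 nM to 140000 nM.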

Compound 4, half-maximal inhibitory concentration: 78800 nM
The estimate for compound 4 lay 1.1-fold (0.05 log units) below the measured number; the range from low to high includes it.
By their numbers in this assay, from the lowest: compounds 1, 4 and 2 (each within the scatter of the next). At a limit, above all of these: compound 3.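

In this assay, trifluoromethyl in place of fluoro on an aromatic carbon gives a 1.1-fold lower number from compound 2 to compound 4 (0.05 log units; within the scatter). Unlike the earlier swap of the whole ring, this change touches a single group on the shared core, and the reading stays within the scatter even though 4 heavy atoms enter where 1 leaves. In this small set, the position para to a large group therefore tolerates both fluoro and trifluoromethyl without a readable shift.

As far as these compounds go, whether any group at this position can move the number beyond the scatter remains open, as fluoro and trifluoromethyl are the only two compared here on an otherwise unchanged core. An amine, a nitrile or a carboxylic acid in the same place could answer that, and so could a longer chain.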